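Nitro on the core ring: a step from a limit

This account rests on a few compounds, and the source may have more. Where it says the series, first, only, none or still open, it means among the compounds named here.

In a functional assay on A549 cells (Homo sapiens) for cytotoxicity, read by MTT assay, with a stated time of 48 h (a higher number here means a weaker inhibitor, a lower number a stronger inhibitor), compound 1 `CCn1c(/C=C2/C(=O)Nc3ccccc32)nc2ccccc21` gives only > 50000 nM, a limit of the assay rather than a number, so its own potency is known only as weak or weaker, as the limit of > 50000 nM in this assay, at which 1 of the 3 values shown sits, records. Compound 2 `CC(C)n1c(/C=C2/C(=O)Nc3ccccc32)nc2ccccc21` gives 35300 nM in this assay, and compound 3 `Cn1c(/C=C2/C(=O)Nc3ccc(Br)cc32)nc2ccccc21` gives 41200 nM; all three are weak inhibitors of this cell growth read-out. Within the data shown here, the only measured step, an at least 1.4-fold lower number from compound 1 to compound 2 (0.15 log units; that floor lies within the scatter), changes a different part of the molecule and so says little about a ring substituent. Compound 4 `CCn1c(/C=C2/C(=O)Nc3ccc([N+](=O)[O-])cc32)nc2ccccc21` differs from compound 1 by nitro in place of hydrogen on an aromatic carbon. Among the measured compounds shown here, no measured pair isolates a nitro group, and the bromine-bearing compound 3 shows that a ring substituent leaves the value in the same weak region. Compound 4 is therefore expected to stay weak, and its value is estimated at 40000 nM with a range from 15000 nM to 100000 nM. The step this implies, an at least 1.2-fold lower number from compound 1 to compound 4 (0.09 log units; that floor lies within the scatter), is expected to lie within the scatter.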

Compound 4, half-maximal inhibitory concentration: > 50000 nM
Compound 4: no number, only a limit; the forecaster's own chance of this, stated with the estimate: 50%; at least 1.2-fold (0.09 log units) between middle value and limit.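

Compound 1 and compound 4 both give only a limit of the assay rather than a number, so the step between them cannot be read: the limit of > 50000 nM in this assay, at which 2 of the 4 values shown sit.

Going by these compounds, whether nitro in place of hydrogen on an aromatic carbon changes the result in this assay at all remains open.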